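A second hydroxy group on compound 1

The compounds below may be only part of what the source reports. "The series", "measured", "known", "first", "only" and "open" are said of these compounds alone.

Compound 1 `Cc1cc(/C=C/c2ccc(O)cc2)[nH]n1` gives 59200 nM
Compound 2 `COc1ccc(/C=C/c2cc(C)n[nH]2)cc1` gives 19900 nM
Compound 3 `COc1ccc(/C=C/c2cc(C)no2)cc1` gives > 100000 nM (a limit of the assay)

These results come from an ADME assay on NIH3T3 cells (Mus musculus) for cytotoxicity, read by MTT assay, with a stated time of 72 h (a lower number here means a stronger inhibitor, a higher number a weaker inhibitor), and compound 1 holds the higher of the two actual numbers, with compound 2 as its nearest neighbour. The result for compound 3 is a limit. Compound 4 `Cc1cc(/C=C/c2ccc(O)c(O)c2)[nH]n1` differs from compound 1 by a single change hydroxy in place of hydrogen on an aromatic carbon with hydroxy in place of hydrogen on an aromatic carbon, ortho to a hydroxy group. Within the data shown here, the only measured step that bears on it, a 3.0-fold lower number from compound 1 to compound 2 (0.47 log units; beyond the scatter) and modest in size, alters that same hydroxy group but is a different change, so it offers only a rough guide. A similarly modest shift is therefore expected, a 2.0-fold lower number from compound 1 to compound 4 (0.30 log units; within the scatter) as the estimate. Compound 4 is estimated at 30000 nM (expected range 10000 nM to 90000 nM).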

Compound 4, half-maximal inhibitory concentration: 88400 nM
For compound 4 the middle estimate is 2.9-fold (0.47 log units) below the measured one; measured number inside the range.
By their numbers in this assay, from the lowest: compound 2; then compounds 1 and 4 (each within the scatter of the next). At a limit, above all of these: compound 3.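

A hydroxy group ortho to a hydroxy group gives a 1.5-fold higher number from compound 1 to compound 4 (0.17 log units; within the scatter), so in this assay this added group produces no change that can be told from the scatter. Methyl in place of hydrogen on the existing hydroxy group moved the number beyond the scatter, whereas this addition on the aromatic carbon does not. The top of the readable range also bears on any further change in this series: the limit of > 100000 nM in this assay, at which 1 of the 4 values shown sits.

The compounds shown leave open whether an amine or a chlorine on this same aromatic carbon would read any differently from hydrogen.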